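Lengthening the Chain Once More

A few compounds are considered here, and "the series" means these few. Any claim that something is new, unique, unknown or untested is made for them only; others in the source may bear on it.

Values in a functional assay on HCT-116 cells (Homo sapiens) for antiproliferative activity, read by MTT assay, with a stated time of 48 h (on this read-out higher numbers stand for weaker inhibition and lower numbers for stronger inhibition), for the measured compounds:
- compound 1 `CCC(CCO)n1cnc2c(Cl)ncnc21` gives > 50000 nM as a limit of the assay and not a number
- compound 2 `CCCCCCC(CCO)n1cnc2c(Cl)ncnc21` gives 11900 nM as its value
- compound 3 `CCCCCCCCC(CCO)n1cnc2c(Cl)ncnc21` gives 1650 nM as its value

Among the numbers shown, compound 3 stands lowest at 1650 nM and its nearest neighbour is compound 2 at 11900 nM on the weaker side. The next analogue, compound 4 `CCCCCCCCCC(CCO)n1cnc2c(Cl)ncnc21` differs from compound 3 by methyl in place of hydrogen on a saturated chain carbon, nine bonds along the chain from an aromatic nitrogen and nothing else.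

Going by the values given here, three measured steps bear on this change, all made on the same chain. The first is an at least 4.2-fold lower number from compound 1 to compound 2 (0.62 log units; beyond the scatter) and it rests on a limit. The second is an at least 30-fold lower number from compound 1 to compound 3 (1.48 log units; beyond the scatter) and it spans the whole series. The closest guide is a 7.2-fold lower number from compound 2 to compound 3 (0.86 log units; beyond the scatter) with ethyl as the added group, so for the smaller methyl a smaller step toward lower numbers is expected in this assay and it may only just clear the scatter. Nothing measured shows whether the fall continues beyond compound 3.

The expected change is a 2.4-fold lower number from compound 3 to compound 4 (0.37 log units; beyond the scatter) as an estimate. The estimated value for compound 4 is 700 nM with an expected range of 250 nM to 2000 nM for a single measurement.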

Compound 4, half-maximal inhibitory concentration: 890 nM
For compound 4 the middle estimate is 1.3-fold (0.10 log units) below the measured one; measured number inside the range.
By their numbers in this assay, from the lowest: compounds 4 and 3 (each within the scatter of the next); then compound 2. At a limit, above all of these: compound 1.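

In this assay, methyl in place of hydrogen on a saturated chain carbon, nine bonds along the chain from an aromatic nitrogen, gives a 1.9-fold lower number from compound 3 to compound 4 (0.27 log units; within the scatter), so this assay cannot tell the two compounds apart, whereas the step of a 7.2-fold lower number from compound 2 to compound 3 (0.86 log units; beyond the scatter) stood clear of the scatter. Measured against a shorter chain, the result is still plain, with a 13-fold lower number from compound 2 to compound 4 (1.13 log units; beyond the scatter), which places compound 4 alongside compound 3 on the stronger side of compound 2. The widest comparison, an at least 56-fold lower number from compound 1 to compound 4 (1.74 log units; beyond the scatter), rests on a limit and not on a number: the limit of > 50000 nM in this assay, at which 1 of the 4 values shown sits.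

From the compounds shown here alone, whether a longer chain would bring the numbers down further, hold them level or send them back up stays open, and a single step within the scatter does not separate a true levelling-off from ordinary variation between repeat measurements. Also open is how an amine or a carboxylic acid in place of the hydroxyl group would behave on these chains, since every compound shown carries that same hydroxyl group and the same core.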